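Aryl swap on the aromatic nitrogen: compound 1 to compound 4

The source may hold more compounds than are shown below. What is called first, only, known or untested is meant among the compounds shown, and "the series" means these compounds.

Measured so far:
compound 1 `CCOC(=O)C1=Cc2ccccc2OC1(OCc1cn(-c2cccc(OC)c2)nn1)C(F)(F)F`: > 150000 nM
compound 2 `O=C(O)C1=Cc2ccccc2OC1(OCc1cc(-c2ccc([N+](=O)[O-])cc2)no1)C(F)(F)F`: > 150000 nM
compound 3 `CCOC(=O)C1=Cc2ccccc2OC1(OCc1cc(-c2ccc(OC)cc2)no1)C(F)(F)F`: > 150000 nM

All three compounds were run in a functional assay on MCF7 cells (Homo sapiens) for inhibition, read by MTT assay, with a stated time of 24 h; on this read-out lower numbers stand for stronger inhibition and higher numbers for weaker inhibition. Compound 1 gives > 150000 nM, which is a limit of this assay and not a number. Compound 2 gives > 150000 nM, again a limit. Compound 3 gives > 150000 nM, also a limit. Compound 1 therefore stands where the whole set stands: the limit of > 150000 nM in this assay, at which 3 of the 3 values shown sit. For the measured compounds named here, since no measured value sits off the limit, no step between measured compounds can be sized, and nothing in the set separates one compound from another.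

Compound 4 `CCOC(=O)C1=Cc2ccccc2OC1(OCc1cn(-c2ccc(F)c(Cl)c2)nn1)C(F)(F)F` differs from compound 1 by 3-chloro-4-fluorophenyl in place of 3-methoxyphenyl on an aromatic nitrogen. The shared core, the ester and the trifluoromethyl group stay as they are. With every measured value at the limit, the expected step in this assay is a step that the limit leaves unreadable from compound 1 to compound 4, that is none beyond the usual scatter. For compound 4 the expected value in this assay is 200000 nM, with a range from 60000 nM to 600000 nM, and most likely it is reported only as a limit again.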

Compound 4, half-maximal inhibitory concentration: 25300 nM
Compound 4: the middle estimate sits 7.9-fold (0.90 log units) above what was measured; the measured number lies below the stated range.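

In this assay, the aryl group on the aromatic nitrogen is the one place shown where a change moves the read-out off the limit: the limit of > 150000 nM in this assay, at which 3 of the 4 values shown sit.

Putting 3-chloro-4-fluorophenyl in place of 3-methoxyphenyl gives an at least 5.9-fold lower number from compound 1 to compound 4 (0.77 log units; beyond the scatter). Compound 1 gives > 150000 nM, which is a limit of the assay and not a number, so this step has a floor but no measured size.

Which part of the change carries the step stays open, since the chlorine and the fluorine enter together as the methoxy leaves; a phenyl carrying only the chlorine or only the fluorine, or an unsubstituted phenyl, on the same nitrogen would separate these parts. As far as these compounds go, whether the gain holds with an amide in place of the ester of compound 4 also remains open.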